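Adding the (1-bromoethenyl)carbonyl group to compound 3

This account rests on a few compounds, and the source may have more. Where it says the series, first, only, none or still open, it means among the compounds named here.

Compound 1 `C=C(Br)C(=O)Nc1ccc(/C=C2\SC(=O)N(Cc3cccc(F)c3)C2=O)cc1`: 5900 nM
Compound 2 `C=C(Br)C(=O)Nc1ccc(/C=C2\SC(=O)N(Cc3ccc(C)cc3)C2=O)cc1`: 8900 nM
Compound 3 `Nc1ccc(/C=C2\SC(=O)N(Cc3ccccc3)C2=O)cc1`: 46000 nM

In a functional assay on HeLa cells (Homo sapiens) for cytotoxicity, read by cell counting, with a stated time of 4 days (a lower number here means a stronger inhibitor, a higher number a weaker inhibitor), compound 3 gives the highest number of the three, and its gaps to compound 2 and to compound 1 both lie beyond the scatter. Compound 4 `C=C(Br)C(=O)Nc1ccc(/C=C2\SC(=O)N(Cc3ccccc3)C2=O)cc1` differs from compound 3 by (1-bromoethenyl)carbonyl in place of hydrogen on a nitrogen on an aromatic ring. Going by the values given here, the only measured step, a 1.5-fold higher number from compound 1 to compound 2 (0.18 log units; within the scatter), concerns the group on a saturated chain carbon bound to an amide-type nitrogen in a ring and does not touch this change. Compounds 1 and 2, which both carry the (1-bromoethenyl)carbonyl group, show lower numbers than compound 3. Compound 4 is therefore expected to move down by a 6.6-fold lower number from compound 3 to compound 4 (0.82 log units; beyond the scatter). The estimate for compound 4 is 7000 nM, between 3000 nM and 16000 nM.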

Compound 4, half-maximal inhibitory concentration: 1000 nM
Beside the measured number, compound 4's estimate is 7.0-fold (0.85 log units) above it; the measured number lies below the stated range.
By their numbers in this assay, from the lowest: compound 4; then compounds 1 and 2 (each within the scatter of the next); then compound 3.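

In this assay, going by these compounds alone, (1-bromoethenyl)carbonyl in place of hydrogen on a nitrogen on an aromatic ring gives a 46-fold lower number from compound 3 to compound 4 (1.66 log units; beyond the scatter), the first direct reading of this change at this position. With that group kept, hydrogen in place of methyl on an aromatic carbon gives an 8.9-fold lower number from compound 2 to compound 4 (0.95 log units; beyond the scatter), and hydrogen in place of fluoro on an aromatic carbon gives a 5.9-fold lower number from compound 1 to compound 4 (0.77 log units; beyond the scatter), so neither substituent lowers the number. Nothing available accounts for the size of these steps.

The compounds shown leave open how an acetyl group on that nitrogen would compare. They also leave open whether chlorine could replace the bromine.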